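Swapping the halophenyl on a urea: what to expect

This account rests on a few compounds, and the source may have more. Where it says the series, first, only, none or still open, it means among the compounds named here.

Measured so far:
Compound 1 `COc1cc2ncnc(NCc3cccc(NC(=O)Nc4ccccc4)c3)c2cc1OC` gives 10000 nM.
Compound 2 `COc1cc2ncnc(NCc3cccc(NC(=O)Nc4ccc(F)cc4)c3)c2cc1OC` gives 42100 nM.

In a functional assay on MGC-803 cells (Homo sapiens) for antiproliferative activity, read by MTT assay (a higher number here means a weaker inhibitor, a lower number a stronger inhibitor), compound 2 stands with the highest number of the two, its nearest neighbour being compound 1 with a lower number. Going by the values given here, the one measured step, a 4.2-fold higher number from compound 1 to compound 2 (0.62 log units; beyond the scatter), is modest but lies beyond the usual scatter. Compound 3 `COc1cc2ncnc(NCc3cccc(NC(=O)Nc4ccccc4Cl)c3)c2cc1OC` differs from compound 2 by 2-chlorophenyl in place of 4-fluorophenyl on an amide-type nitrogen. That measured step bears on this change only in part: it added a fluoro to an otherwise plain phenyl, whereas here the fluoro is removed and a chloro enters at another place on the same ring. Because compound 1 gave 10000 nM without any halogen, a return toward that number seems as likely as staying put, so the expected step of a 2.1-fold lower number from compound 2 to compound 3 (0.32 log units; beyond the scatter) is small. The estimate for compound 3 is 20000 nM, within a range of 6000 nM to 70000 nM.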

Compound 3, half-maximal inhibitory concentration: 30200 nM
Compound 3: middle estimate off by 1.5-fold (0.18 log units), on the low side; low and high end bracket the measured number.
By their numbers in this assay, from the lowest: compound 1; then compounds 3 and 2 (each within the scatter of the next).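

In this assay, putting 2-chlorophenyl in place of 4-fluorophenyl on the amide-type nitrogen brings a 1.4-fold lower number from compound 2 to compound 3 (0.14 log units; within the scatter) and so leaves these two compounds indistinguishable. Set against the plain phenyl ring, the chloro brings a 3.0-fold higher number from compound 1 to compound 3 (0.48 log units; beyond the scatter) and so shows that a second halogen, at another place on the ring, also separates from compound 1, which has the lowest number of the three. Nothing available explains why either halogen goes with a higher number than hydrogen.

Halogen and ring place changed together from compound 2 to compound 3, so the effect of each alone stays open, and 4-chlorophenyl or 2-fluorophenyl would pull them apart. As far as these compounds go, whether a non-halogen group, such as a methyl or an amine, would also give a higher number than compound 1 remains open too.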